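This account rests on a few compounds, and the source may have more. Where it says the series, first, only, none or still open, it means among the compounds named here.

Measured so far:
- compound 1, `C[C@@H](NC(=O)Nc1ccccc1F)c1ccccc1`, 77%
- compound 2, `C[C@@H](NC(=O)Nc1ccc(F)cc1)c1ccccc1`, 92%
- compound 3, `C[C@@H](NC(=O)Nc1c(F)cccc1F)c1ccccc1`, 98%

All three were tested in an ADME assay on the whole organism with Oryza sativa as the target, tested at 10 uM; on this read-out lower numbers stand for a stronger effect and higher numbers for a weaker effect at the one concentration tested. Compounds 1 and 3 share a core and differ in one place: fluoro in place of hydrogen on an aromatic carbon. This change gave a number 21 percentage points higher from compound 1 to compound 3 (beyond the scatter). Compound 2 has the same atoms as compound 1 joined differently; the difference between the two cores is not broken down here. Compound 2 and compound 3 give values that lie within the scatter of each other, so nothing can be said about which has the stronger effect; compound 2 sits beyond the scatter above compound 1.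

Compound 4, `C[C@@H](NC(=O)Nc1ccc(F)c(F)c1)c1ccccc1`, has not yet been measured. It differs from compound 2 in one place: fluoro in place of hydrogen on an aromatic carbon. Among the compounds with values here, this is the same kind of change as the one from compound 1 to compound 3, but not the same: there the entering fluoro sat ortho to a large group and meta to a fluoro group, whereas here it sits ortho to a fluoro group and meta to a large group. Compound 2 already gives a high reading in this assay, so there is little room for a step as large as the earlier one. From compound 2 to compound 4 the expected step is a number 4 percentage points higher from compound 2 to compound 4 (within the scatter), resting on the earlier step of a number 21 percentage points higher from compound 1 to compound 3 (beyond the scatter) and on the starting value of compound 2, which gives 92%. For compound 4 the estimate is 96%, with a likely range from 87% to 102%.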

Compound 4, a percentage reported as activity, at one concentration (the size of the read-out at that concentration, not a potency): 96%
Compound 4: middle estimate and measured number agree at the digits printed; measured number inside the range.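

In this assay, the same swap of hydrogen for fluoro on an aromatic carbon gave a number 4 percentage points higher from compound 2 to compound 4 (within the scatter), so on this second core the change leaves the reading indistinguishable from that of its parent. Set beside the earlier step, the change clearly did not carry over at the same size from one core to the other: the same change on two cores in this assay, a number 21 percentage points higher (beyond the scatter) from compound 1 to compound 3 and a number 4 percentage points higher (within the scatter) from compound 2 to compound 4, 17 percentage points apart, beyond the scatter of two such steps This shows that, in this series, the size of the step cannot simply be copied across cores, but with only two pairs it does not show what sets the size, since the pairs differ in the core, in the place where the fluoro enters, and in the starting value, with compound 1 at 77% and compound 2 at 92%.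

The compounds shown leave open whether the step would stay this small or grow again if the same fluoro entered other places on these cores, which would help separate the role of place from that of the starting value. They also leave open how other groups would read in this assay, such as a chlorine atom, a methoxy group or an amine on the aromatic ring in place of fluoro.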